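The source may hold more compounds than are shown below. What is called first, only, known or untested is meant among the compounds shown, and "the series" means these compounds.

Two compounds of this series have so far been run in an ADME assay on liver (Homo sapiens) for metabolic stability, read by LC-MS, using S9 fraction, tested at 2 uM; a lower number here means slower removal, a higher number faster removal of the compound. Compound 1 `CCCCc1ccc(NC(=O)COc2cc(C)nc3ccc(OC)cc23)cc1` gives 16.3 mL/min/kg in this assay, and compound 2 `COc1ccc2nc(C)cc(OCC(=O)Nc3ccc4c(c3)CCC4)c2c1` gives 16.9 mL/min/kg. Compound 2 therefore stands at a number that lies within the usual scatter of compound 1, so the two cannot be told apart on the numbers shown. Compound 3 `COc1ccc2nc(C)cc(OCC(=O)Nc3ccc(C)c(C)c3)c2c1` has not yet been measured in this assay. It differs from compound 2 in one place only: 3,4-dimethylphenyl in place of 2,3-dihydro-1H-inden-5-yl on an amide-type nitrogen. No pair of measured compounds that differ in just this way is available, so the size of the step cannot be read from other pairs. The expectation is of no step beyond the scatter in either direction, with an estimated step of a 1.0-fold higher number from compound 2 to compound 3 (0.00 log units; within the scatter) in this assay. For compound 3 the estimated clearance in this assay is 17 mL/min/kg, with a range from 9 mL/min/kg to 34 mL/min/kg.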

Compound 3, clearance: 16.2 mL/min/kg
For compound 3 the middle estimate is 1.0-fold (0.02 log units) above the measured one; low and high end bracket the measured number.
By their numbers in this assay, from the lowest: compounds 3, 1 and 2 (each within the scatter of the next).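

In this assay, among these compounds, 3,4-dimethylphenyl in place of 2,3-dihydro-1H-inden-5-yl on the amide-type nitrogen gives a 1.0-fold lower number from compound 2 to compound 3 (0.02 log units; within the scatter) and is the first single-place change that can be read. On this nitrogen, the five-membered non-aromatic ring of carbon only can therefore give way to two separate methyl groups on the aromatic ring with no step beyond the scatter in clearance. Nothing available bears on why these two groups read alike.

From the compounds shown here alone, it remains open whether either methyl group of 3,4-dimethylphenyl matters on its own, or whether a plain phenyl would read the same. Going by these compounds, it is also open whether an aromatic ring carrying an amine or a carboxylic acid on this nitrogen would produce a step beyond the scatter.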